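Adding a chloro group to compound 2

A few compounds are considered here, and "the series" means these few. Any claim that something is new, unique, unknown or untested is made for them only; others in the source may bear on it.

Measured in a functional assay on KB cells (Homo sapiens) for inhibition, read by MTT assay, with a stated time of 24 h, tested at 10 ug/mL; a lower number here means less inhibition of growth, a higher number more inhibition of growth at the concentration tested:
- compound 1 `O=C(CCCCC(S)CCS)NO`: 41.5%
- compound 2 `O=C(CCCCC(S)CCS)Nc1ccccc1`: 8.62%
- compound 3 `O=C(CCCCC(S)CCS)Nc1ccccc1Cl`: "not active" (no number reported)

Compound 2 holds the lower of the two numbers in this assay, and compound 1 stands well above it. Compound 3 has no number and cannot be placed on that scale.

The next compound is compound 4 `O=C(CCCCC(S)CCS)Nc1cccc(Cl)c1`, not yet measured. Its difference from compound 2 is chloro in place of hydrogen on an aromatic carbon.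

Among the compounds with values here, only one measured step has a number: a number 32.9 percentage points lower from compound 1 to compound 2 (beyond the scatter). That step is large, but it is phenyl in place of hydroxy on an amide-type nitrogen, so it gives no size for a change on the aromatic ring. The nearest evidence is compound 3, which also carries a chloro group on that ring and is reported as "not active" (no number reported). Compound 2 itself gives only 8.62%, which leaves little room for a fall. No step beyond the scatter is therefore expected in this assay, and any small shift is expected to be downward. A report without a number also remains possible.

The estimated change is a number 1.6 percentage points lower from compound 2 to compound 4 (within the scatter). For compound 4 the expected value is 7%, with an estimated range from 0% to 18%.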

Compound 4, percent growth inhibition at one concentration: "not active" (no number reported)
The entry for compound 4 holds no number, and the estimate cannot be compared.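

Within the data shown here, compound 4, like compound 3, is reported in this assay without a number, so no step from compound 2 to either compound can be read. No measured evidence bears on this result. The compounds shown leave open how large any change in growth inhibition is when a chloro group is added to the aromatic ring of compound 2.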